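Urea in place of benzamide on a pyrazole scaffold

The source may report more compounds than this note shows. Statements on the series, on what has been measured and on what is new or still open speak of the compounds shown alone.

Measured compounds:
compound 1, `O=C(Nc1cccc(-n2cc(-c3ccncc3)c(-c3ccc(Cl)c(O)c3)n2)c1)Nc1ccc(Cl)c(Cl)c1`, 930 nM
compound 2, `COc1cc(-c2nn(-c3cccc(NC(=O)c4cccc(C(F)(F)F)c4)c3)cc2-c2ccncc2)ccc1Cl`, 27900 nM
compound 3, `COc1cc(-c2nn(-c3cccc(NC(=O)c4ccccc4)c3)cc2-c2ccncc2)ccc1Cl`, 859 nM

In a functional assay on UACC-257 cells (Homo sapiens) for inhibition, read by sulforhodamine B assay, with a stated time of 48 h (on this read-out lower numbers stand for stronger inhibition of growth and higher numbers for weaker inhibition of growth), compound 3 stands lowest of the three numbers, though compound 1 sits within the scatter of it and only compound 2 lies clearly apart. Within the data shown here, the one step in the set, a 32-fold lower number from compound 2 to compound 3 (1.51 log units; beyond the scatter), shows that the group on the carbonyl carbon can move the number a great deal.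

Compound 4, `COc1cc(-c2nn(-c3cccc(NC(=O)Nc4ccc(Cl)c(Cl)c4)c3)cc2-c2ccncc2)ccc1Cl`, has not yet been measured. It differs from compound 3 in one place: (3,4-dichlorophenyl)amino in place of phenyl on a carbonyl carbon. Among the measured compounds shown here, no measured step covers this exchange directly, so the step from compound 2 to compound 3 is the only guide to how sensitive this position is, and it bears on the expectation only in that sense. The ((3,4-dichlorophenyl)carbamoyl)amino group of compound 4 also appears in compound 1, whose value of 930 nM in this assay lies close to that of compound 3, although the two share no listed step and their cores differ elsewhere.

On this basis compound 4 is expected to remain near compound 3, with an estimated step of a 1.0-fold higher number from compound 3 to compound 4 (0.02 log units; within the scatter). The estimate for compound 4 is 900 nM, with a range from 300 nM to 3000 nM.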

Compound 4, concentration for 50% growth inhibition: 1040 nM
For compound 4 the middle estimate is 1.2-fold (0.06 log units) below the measured one, within the range that was stated.
By their numbers in this assay, from the lowest: compounds 3, 1 and 4 (each within the scatter of the next); then compound 2.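

In this assay, the exchange of benzamido for ((3,4-dichlorophenyl)carbamoyl)amino on the shared core (a 1.2-fold higher number from compound 3 to compound 4 (0.08 log units; within the scatter)) leaves the number within the scatter, so at this position a urea with a substituted aryl group reads the same as the plain benzamide. The large effect seen earlier therefore does not extend to every substituted aryl group at this carbonyl carbon: (3,4-dichlorophenyl)amino in place of 3-(trifluoromethyl)phenyl also gives a clear change (a 27-fold lower number from compound 2 to compound 4 (1.43 log units; beyond the scatter)), and among the compounds shown only compound 2 stands apart. Among these compounds, with the urea held constant, methyl in place of hydrogen on the oxygen on the aromatic ring also stays within the scatter (a 1.1-fold higher number from compound 1 to compound 4 (0.05 log units; within the scatter)), which links compound 1 directly to this series for the first time.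

No measurement shown accounts for any of these steps. From the compounds shown here alone, it remains open whether the urea with an unsubstituted phenyl or with a 3-(trifluoromethyl)phenyl group, or an amide bearing an amine or a carboxylic acid on its phenyl ring, would hold the number in this range.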